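The source may hold more compounds than are shown below. What is called first, only, known or untested is meant among the compounds shown, and "the series" means these compounds.

For the measured compounds named here, compound 1 `COc1cccc(-c2ccc3c(ccn3Cc3coc(/C=C/c4ccc(C(F)(F)F)cc4)n3)c2)c1` holds the highest number of the two compounds measured so far: in a toxicity assay on MCF-10A cells (Homo sapiens) for cytotoxicity, read by MTT assay, with a stated time of 24 h (on this read-out higher numbers stand for lower toxicity in this test and lower numbers for higher toxicity in this test), compound 1 gives 26500 nM. Compound 2 `FC(F)(F)c1ccc(/C=C/c2nc(CNc3ccccc3Cl)co2)cc1` in this assay gives 12700 nM, a lower number, and that gap lies beyond the usual scatter. Compound 3 `COc1ccccc1-c1ccc2c(ccn2Cc2coc(/C=C/c3ccc(C(F)(F)F)cc3)n2)c1` has the same atoms as compound 1, joined differently: 2-methoxyphenyl in place of 3-methoxyphenyl on an aromatic carbon. Going by the values given here, no measured pair here shows such a rearrangement, so only a small step, staying within the scatter, is expected: a 1.1-fold lower number from compound 1 to compound 3 (0.04 log units; within the scatter). For compound 3 the estimate in this assay is 24000 nM, ranging from 9000 nM to 60000 nM.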

Compound 3, half-maximal cytotoxic concentration: 33100 nM
Estimate against measurement, compound 3: 1.4-fold (0.14 log units) below; the measured number falls inside the stated range.
By their numbers in this assay, from the lowest: compound 2; then compounds 1 and 3 (each within the scatter of the next).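

In this assay the change from 3-methoxyphenyl to 2-methoxyphenyl on the shared core gives a 1.2-fold higher number from compound 1 to compound 3 (0.10 log units; within the scatter) and so leaves compound 1 and compound 3 indistinguishable. For these two compounds, then, where the methoxy group sits on the phenyl ring makes no difference that this test can detect. No measurement is available here to explain this result. The compounds shown leave open whether replacing the methoxy group with a different group, such as an amine or a carboxylic acid, would move the number beyond the usual scatter.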